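The source may report more compounds than this note shows. Statements on the series, on what has been measured and on what is new or still open speak of the compounds shown alone.

Compound 2 `Cc1cccc(CNCc2cc(=O)c3c(O)c(O)ccc3o2)c1` has been tested in an ADME assay on Huh-7 cells (Homo sapiens) for cytotoxicity; on this read-out lower numbers stand for higher toxicity in this test and higher numbers for lower toxicity in this test. In that test compound 2 gives > 100000 nM, and this is a limit of the assay rather than a number. Compound 1 `O=c1cc(CNCc2cccc(F)c2)oc2ccc(O)c(O)c12` shares the whole core and differs from compound 2 only by a methyl in place of fluoro on an aromatic carbon. In this assay compound 1 gives > 100000 nM, which is again a limit. The step that the two limits leave unreadable from compound 1 to compound 2 cannot be given a size because of the limit of > 100000 nM in this assay, at which 2 of the 2 values shown sit. Compound 3 `O=c1cc(CNCc2ccc(F)cc2)oc2ccc(O)c(O)c12` has not yet been measured. It differs from compound 2 by 4-fluorophenyl in place of 3-methylphenyl on a saturated chain carbon bound to an amine nitrogen. For the measured compounds named here, no measured step follows this exact exchange; the only measured step, a step that the two limits leave unreadable from compound 1 to compound 2, swaps a fluoro and a methyl on an aromatic carbon, and its size is unreadable. Going by the values given here, since the two values so far sit at the same limit, the expected step is a number no higher from compound 2 to compound 3 (the limit leaves the size open), within the scatter, and the result is expected to be once more a limit. Compound 3 is therefore estimated at 100000 nM in this assay, with a range from 40000 nM to 250000 nM.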

Compound 3, half-maximal cytotoxic concentration: > 100000 nM
Compound 3 was reported as a limit; the forecaster's own chance of this, stated with the estimate: 85%; the middle value lies on the limit itself.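

No size can be given for any step among compound 1, compound 2 and compound 3 in this assay, because each result is a limit of the assay and not a number: the limit of > 100000 nM in this assay, at which 3 of the 3 values shown sit.

The compounds shown leave open whether exchanging the 3-fluorophenyl, 3-methylphenyl and 4-fluorophenyl groups makes any difference to the result in this assay, and how large such a difference would be.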